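Changing the Amide Cap of Compound 2

This account rests on a few compounds, and the source may have more. Where it says the series, first, only, none or still open, it means among the compounds named here.

Three compounds have been measured in an in vitro assay on LLC-PK1 cells for displacement of a labelled ligand from growth hormone secretagogue receptor type 1 (Homo sapiens); on this read-out lower numbers stand for stronger inhibition and higher numbers for weaker inhibition:

Compound 1 `CCc1ccc(-n2c(CCc3c[nH]c4ccccc34)nnc2[C@H](NC(=O)c2ccccn2)c2c[nH]c3ccccc23)cc1`: 49 nM
Compound 2 `COc1ccc(Cn2c(CCc3c[nH]c4ccccc34)nnc2[C@H](NC(=O)c2ccccn2)c2c[nH]c3ccccc23)cc1`: 1.9 nM
Compound 3 `O=C(N[C@H](c1c[nH]c2ccccc12)c1nnc(CCc2c[nH]c3ccccc23)n1-c1ccccc1)c1ccccn1`: 160 nM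

Compound 2 gives the lowest number of the three; the steps of a 26-fold lower number from compound 1 to compound 2 (1.41 log units; beyond the scatter) and an 84-fold higher number from compound 2 to compound 3 (1.93 log units; beyond the scatter) both lie beyond the scatter, as does a 3.3-fold higher number from compound 1 to compound 3 (0.51 log units; beyond the scatter). Compound 4 `COc1ccc(Cn2c(CCc3c[nH]c4ccccc34)nnc2[C@H](NC(=O)Cc2ccncc2)c2c[nH]c3ccccc23)cc1` differs from compound 2 by (pyridin-4-yl)methyl in place of pyridin-2-yl on a carbonyl carbon. Going by the values given here, none of the measured steps touches this part of the molecule: all three concern the group on the aromatic nitrogen or the ethyl on the aromatic carbon. The expectation for compound 4 therefore rests on the value of compound 2 alone, and a step of a 4.2-fold higher number from compound 2 to compound 4 (0.62 log units; beyond the scatter) toward a higher number is expected, with wide uncertainty. Compound 4 is estimated at 8 nM, in a range from 2 nM to 40 nM.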

Compound 4, half-maximal inhibitory concentration: 76 nM
Estimate against measurement, compound 4: 9.5-fold (0.98 log units) below, outside the stated range (above it).
By their numbers in this assay, from the lowest: compound 2; then compounds 1 and 4 (each within the scatter of the next); then compound 3.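

The amide cap is a sensitive position in this assay: with the 4-methoxybenzyl group kept, (pyridin-4-yl)methyl in place of pyridin-2-yl on the carbonyl carbon gives a 40-fold higher number from compound 2 to compound 4 (1.60 log units; beyond the scatter). Going by these compounds alone, the earlier steps concerned only other parts of the molecule, so this is the first sign that the number also responds to this cap. Nothing available here explains the step.

The step combines an added methyl link with a change from pyridin-2-yl to a pyridin-4-yl ring, and the compounds shown do not separate the two. As far as these compounds go, how pyridin-4-yl or (pyridin-4-yl)ethyl on that carbonyl carbon would read remains open.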